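Cytotoxicity notes: amino removal on the shared core

A few compounds are considered here, and "the series" means these few. Any claim that something is new, unique, unknown or untested is made for them only; others in the source may bear on it.

Compound 1 `C#Cc1cn([C@@H]2O[C@H](CO)[C@@H](O)[C@H]2O)c2ncnc(OC)c12` and compound 2 `COc1nc(N)nc2c1c(-c1ccco1)cn2[C@@H]1O[C@H](CO)[C@@H](O)[C@H]1O` carry the same sugar on closely related cores; compound 3 `COc1ncnc2c1c(-c1ccco1)cn2[C@@H]1O[C@H](CO)[C@@H](O)[C@H]1O` is the next member and has no result yet. In an ADME assay on MRC5 cells (Homo sapiens), read by MTT assay, with a stated time of 72 h (a higher number here means a weaker inhibitor, a lower number a stronger inhibitor), compound 1 reaches only a limit, > 100000 nM. In this assay, among the measured compounds shown here, compound 2 gives 89700 nM, which is the only number in the set. The other result sits at the limit of > 100000 nM in this assay, at which 1 of the 2 values shown sits. Compound 2 thus stands as a weak inhibitor by the one number shown, with no other measured step to compare against.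

Compound 3 differs from compound 2 in one place: hydrogen in place of amino on an aromatic carbon. For the measured compounds named here, no measured step between compounds that differ in one place exists here, so the size of this change is not anchored by data. Compound 2 gives 89700 nM in this assay. Compound 1 sits only at a limit. On that basis the step from compound 2 to compound 3 is expected to stay within the scatter, a 1.0-fold higher number from compound 2 to compound 3 (0.00 log units; within the scatter), with no direction favoured. Compound 3 is therefore estimated at 90000 nM in this assay, in the range 35000 nM to 230000 nM, with a fair chance that only a limit is reported.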

Compound 3, half-maximal inhibitory concentration: 1700 nM
For compound 3 the middle estimate is 53-fold (1.72 log units) above the measured one; measured number outside the range, below it.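

The amino group on the aromatic carbon between two ring nitrogen atoms proves to be a strong determinant of the read-out in this assay: with the furan-2-yl and methoxy groups unchanged, hydrogen in its place gives a 53-fold lower number from compound 2 to compound 3 (1.72 log units; beyond the scatter), which turns a weak inhibitor into a much stronger one. With hydrogen at that carbon, the second one-place comparison also shows a large change, with furan-2-yl in place of ethynyl on an aromatic carbon giving an at least 58-fold lower number from compound 1 to compound 3 (1.76 log units; beyond the scatter), so neither group on the shared core is neutral in this series. That second step has only an open-ended size, and compound 1 stands at a limit and not at a number: the limit of > 100000 nM in this assay, at which 1 of the 3 values shown sits.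

The amino step is read only with furan-2-yl present and the furan-2-yl step only with hydrogen present, so the compounds shown leave open whether either change would carry the same size with the other group swapped, as in an amino core bearing ethynyl. They also leave open what a methyl, a chlorine or a dimethylamino group would give on the carbon between two ring nitrogen atoms, and whether the trend is graded or specific to hydrogen.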